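A few compounds are considered here, and "the series" means these few. Any claim that something is new, unique, unknown or untested is made for them only; others in the source may bear on it.

Of the compounds shown here, three with a shared core have been tested in an ADME assay on microsomes from liver (Rattus norvegicus) for metabolic stability, using NADPH, with a stated time of 10 min; on this read-out higher numbers stand for a more stable compound and lower numbers for a less stable compound: compound 1 `NC/C=C\CN(C[C@H]1Cc2ncccc2CN1)[C@H]1CCCc2cccnc21` gives 11%, compound 2 `NC(=O)NCCCCN(C[C@H]1Cc2ncccc2CN1)[C@H]1CCCc2cccnc21` gives 1%, and compound 3 `c1cnc2c(c1)CN[C@@H](CN(CCCCNC1CCOCC1)[C@H]1CCCc3cccnc31)C2` gives 49%, the highest of the three. Compound 4 `c1cnc2c(c1)CN[C@@H](CN(CCCCNC1COC1)[C@H]1CCCc3cccnc31)C2` differs from compound 3 in one group, with oxetan-3-yl in place of oxan-4-yl on an amine nitrogen. Among the compounds with values here, two measured steps bear on this place, and both are large: a number 38 percentage points higher from compound 1 to compound 3 (beyond the scatter) and a number 48 percentage points higher from compound 2 to compound 3 (beyond the scatter). Changes here can therefore matter, but neither step swaps one non-aromatic ring for another, so neither gives a direct size. The expected a number 3 percentage points higher from compound 3 to compound 4 (within the scatter) is thus a change within the scatter, in no clear direction. For compound 4 the estimate is 52%, with an expected range from 30% to 74%.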

Compound 4, percent of the compound remaining: 27%
Compound 4: the middle estimate sits 25 percentage points above what was measured, and the stated range ends above it.
By their numbers in this assay, from the lowest: compounds 2 and 1 (each within the scatter of the next); then compound 4; then compound 3.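

Within the data shown here, this is the first direct swap of one non-aromatic ring for another on this amine nitrogen, and ring size turns out to matter here: in this assay the change from oxan-4-yl to oxetan-3-yl gives a number 22 percentage points lower from compound 3 to compound 4 (beyond the scatter) and so is not a neutral exchange. The oxetan-3-yl side chain still compares well with the two open-chain groups, with a number 26 percentage points higher from compound 2 to compound 4 (beyond the scatter) and a number 16 percentage points higher from compound 1 to compound 4 (beyond the scatter) on the same read-out. Going by these compounds, what a five-membered oxolan-3-yl ring or an all-carbon cyclohexyl ring would give on this nitrogen stays open. Nothing measured here explains the drop.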